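The source may report more compounds than this note shows. Statements on the series, on what has been measured and on what is new or still open speak of the compounds shown alone.

In a functional assay on the whole organism (artery) with Rattus norvegicus as the target, with a stated time of 60 min, at a dose of 3 mg/kg by the intraduodenal route (a higher number here means more inhibition at the dose given (going by the name of the read-out), a lower number less inhibition), three close relatives have been examined. Compound 1 `Cc1nc(C)c2c(n1)N(Cc1ccc(-c3ccccc3-c3nn[nH]n3)cc1)C(=O)C(C)(C)C2` gives -66% and compound 3 `Cc1nc(C)c2c(n1)N(Cc1ccc(-c3ccccc3-c3nn[nH]n3)cc1)CCC2` gives -20%, while compound 2 `CCCc1nc(C)nc2c1CCC(=O)N2Cc1ccc(-c2ccccc2-c2nn[nH]n2)cc1` gives -86%, the lowest of the three numbers, a gap to compound 1 and to compound 3 that in each case lies beyond the usual scatter. The next member, compound 4 `CCc1nc(C)nc2c1CCC(=O)N2Cc1ccc(-c2ccccc2-c2nn[nH]n2)cc1`, has not been measured; it differs from compound 2 in one place: hydrogen in place of methyl on a saturated chain carbon, two bonds along the chain from an aromatic carbon. Going by the values given here, no pair of measured compounds shares this exact change, so no measured step guides the expectation; a step of modest size is expected from compound 2 to compound 4 a number 11 percentage points higher from compound 2 to compound 4 (beyond the scatter), possibly within the scatter. Compound 4 is therefore expected to give about -75%, most likely between -100% and -45%.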

Compound 4, a percentage reported as inhibition, in the whole organism at one dose (the size of the read-out at that dose, not a potency) in the Rattus norvegicus assay: -104%
For compound 4 the middle estimate is 29 percentage points above the measured one, and the stated range ends above it.
By their numbers in the Rattus norvegicus assay, from the lowest: compound 4; then compound 2; then compound 1; then compound 3.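

Going by these compounds alone, in the Rattus norvegicus assay the change from propyl to ethyl gives a number 18 percentage points lower from compound 2 to compound 4 (beyond the scatter), the first step here read at a single place, and it shows that the read-out responds to this saturated chain. In a physicochemical assay for lipophilicity (a higher number here means a more lipophilic compound, a lower number a more polar compound), compound 2 gives 4.45 and compound 4 gives 3.92, so the same change also moves the partition coefficient: the measured partition coefficient of compound 2, 4.45, and of compound 4, 3.92, a number 0.53 log units lower (beyond the scatter)

One pair cannot tell whether the two shifts are linked. On these data alone, how a longer chain such as butyl, or a chain ending in an amine, would behave at this place remains open.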